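Swapping the Ester Tail of a Vinylsulfonamide Ester

The source may hold more compounds than are shown below. What is called first, only, known or untested is meant among the compounds shown, and "the series" means these compounds.

Measured compounds:
compound 1, `COc1cc(O)c(C(=O)OCC2CCCCC2)c(/C=C/CN2C(=O)C=CC2=O)c1`, 6.9%
compound 2, `C=CS(=O)(=O)NC/C=C/c1cc(OC)cc(O)c1C(=O)OCC1CCCCC1`, 31.2%
compound 3, `CCN(CC)C/C=C/C(=O)NC/C=C/c1cc(OCCc2ccc(F)cc2)cc(O)c1C(=O)OC(C)C`, 28.5%

In an ADME assay on HEK-293T cells (Homo sapiens) for inhibition, read by luminescence, with a stated time of 72 h, tested at 5 uM (a lower number here means less inhibition of growth, a higher number more inhibition of growth at the concentration tested), compound 2 gives the highest of the three numbers, yet compound 3 sits within the scatter of it, so no order between these two is claimed; compound 1 lies clearly lower, as a number 24.3 percentage points higher from compound 1 to compound 2 (beyond the scatter) shows. Compound 4, `C=CS(=O)(=O)NC/C=C/c1cc(OC)cc(O)c1C(=O)OCC(C)c1ccccc1`, is not yet measured. It differs from compound 2 in one place: 1-phenylethyl in place of cyclohexyl on a saturated chain carbon bound to an oxygen next to a carbonyl group. Among the compounds with values here, the only measured step, from compound 1 to compound 2, alters the chain bound to the double-bonded carbon and leaves the cyclohexylmethoxy side untouched, so no measured step speaks to the change made here. Compound 4 is therefore expected to stay within the scatter of compound 2, an expected step of a number 1.2 percentage points lower from compound 2 to compound 4 (within the scatter). Compound 4 is estimated at 30%, between 14% and 46%.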

Compound 4, percent growth inhibition at one concentration: 22.5%
The estimate for compound 4 lay 7.5 percentage points above the measured number; the measured number falls inside the stated range.
By their numbers in this assay, from the lowest: compound 1; then compounds 4, 3 and 2 (each within the scatter of the next).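

In this assay, 1-phenylethyl in place of cyclohexyl on a saturated chain carbon bound to an oxygen next to a carbonyl group gives a number 8.7 percentage points lower from compound 2 to compound 4 (within the scatter). For this one pair, then, an aromatic ring in place of a non-aromatic ring at this place moves the number by no more than the scatter. No measurement at hand gives a cause for this step. Open, going by these compounds, is whether an amine or a carboxylic acid on this ester chain would leave the number as little moved. Also open, on these data alone, is whether the same swap would behave alike on the core of compound 1 .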